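Returning From Urea to Amide on the Carbonyl Carbon

This account rests on a few compounds, and the source may have more. Where it says the series, first, only, none or still open, it means among the compounds named here.

Three measured compounds share one core and differ only in the group on a carbonyl carbon. Compound 1 `O=C(Nc1nn(-c2ccccc2)c(=O)c2ccccc12)c1ccccc1` carries a plain phenyl there, and in an assay on CHO cells for displacement of a labelled ligand from adenosine receptor A1 (Homo sapiens), tested at 10 uM (a higher number here means more inhibition at the concentration tested (going by the name of the read-out), a lower number less inhibition), compound 1 gives 44%. Compound 2 `O=C(Nc1ccccc1Cl)Nc1nn(-c2ccccc2)c(=O)c2ccccc12` carries a (2-chlorophenyl)amino instead, and in this assay compound 2 gives 0%. Compound 3 `COc1ccc(NC(=O)Nc2nn(-c3ccccc3)c(=O)c3ccccc23)cc1` carries a (4-methoxyphenyl)amino, and in this assay compound 3 gives 4%. Compound 3 thus stands second highest of the three, with compound 2 within the scatter of it and compound 1 far higher. The steps that brought in the amino-bearing groups were both large: a number 44 percentage points lower from compound 1 to compound 2 (beyond the scatter) and a number 40 percentage points lower from compound 1 to compound 3 (beyond the scatter), whereas a number 4 percentage points higher from compound 2 to compound 3 (within the scatter).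

Compound 4 `O=C(Nc1nn(-c2ccccc2)c(=O)c2ccccc12)c1ccc(Cl)cc1` has not yet been measured. The change is 4-chlorophenyl in place of (4-methoxyphenyl)amino on a carbonyl carbon. This reverses the kind of change seen in the step from compound 1 to compound 3, so a large rise is expected, roughly back toward the level of compound 1. Compound 4 is expected to give about 40%, in a range from 20% to 60%. The estimate thus means the step of a number 36 percentage points higher from compound 3 to compound 4 (beyond the scatter).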

Compound 4, a percentage reported as inhibition, at one concentration (the size of the read-out at that concentration, not a potency): 26%
Estimate against measurement, compound 4: 14 percentage points above, and the stated range covers the measured number.
By their numbers in this assay, from the lowest: compounds 2 and 3 (each within the scatter of the next); then compound 4; then compound 1.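

In this assay the return from urea to amide on the carbonyl carbon brings a number 22 percentage points higher from compound 3 to compound 4 (beyond the scatter) and also a number 26 percentage points higher from compound 2 to compound 4 (beyond the scatter) so the rise appears with either amino-bearing group as the starting point. The amide alone does not settle the outcome, since the chloro in place of hydrogen on an aromatic carbon gives a number 18 percentage points lower from compound 1 to compound 4 (beyond the scatter) even though both compounds keep the amide. The position therefore responds to the aromatic group on the carbonyl carbon as well as to the amino nitrogen, and compound 4 recovers only part of the ground separating the ureas from compound 1.

As far as these compounds go, whether a fluoro in place of the chloro, or a cyclohexyl in place of the whole 4-chlorophenyl, would hold the number near that of compound 4 remains open. Nothing available here explains any of these steps.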